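Alkynyl bicyclic series: pyridin-4-yl replacing ethoxy

The compounds below may be only part of what the source reports. "The series", "measured", "known", "first", "only" and "open" are said of these compounds alone.

Measured so far:
compound 1, `O=S(=O)(Nc1ccc(F)c(C#Cc2cnc3[nH]ccc3c2)c1F)c1cccnc1`, 1170 nM
compound 2, `CCOc1n[nH]c2ncc(C#Cc3c(F)ccc(NS(=O)(=O)c4cccnc4)c3F)cc12`, 1980 nM

In a functional assay on COLO 205 cells (Homo sapiens) for antiproliferative activity, read by MTT assay, with a stated time of 68 h (on this read-out higher numbers stand for weaker inhibition and lower numbers for stronger inhibition), compound 2 gives 1980 nM, and compound 1 gives 1170 nM; the gap between them lies within the scatter, so the two do not separate. The two cores differ in more than one place, so no single step can be read from them. Compound 3, `O=S(=O)(Nc1ccc(F)c(C#Cc2cnc3[nH]nc(-c4ccncc4)c3c2)c1F)c1cccnc1`, carries pyridin-4-yl in place of ethoxy on an aromatic carbon. Nothing measured shows the effect of such a change here, so no step beyond the scatter is expected, a 1.3-fold lower number from compound 2 to compound 3 (0.12 log units; within the scatter). Compound 3 is estimated at 1500 nM, within 400 nM to 6000 nM.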

Compound 3, half-maximal inhibitory concentration: 78 nM
Beside the measured number, compound 3's estimate is 19-fold (1.28 log units) above it, and the stated range ends above it.
By their numbers in this assay, from the lowest: compound 3; then compounds 1 and 2 (each within the scatter of the next).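

In this assay, pyridin-4-yl in place of ethoxy on this aromatic carbon of the five-membered ring gives a 25-fold lower number from compound 2 to compound 3 (1.40 log units; beyond the scatter). Among these compounds, this is the first step beyond the scatter, and it shows that the group at this position can strongly shift the antiproliferative read-out. Nothing at hand accounts for the shift.

On these data alone, whether the nitrogen of pyridin-4-yl matters remains open: a phenyl group on the same carbon would separate its contribution from that of the aromatic ring. As far as these compounds go, how an amine or pyridin-3-yl would read here is also open.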